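The source may hold more compounds than are shown below. What is called first, only, known or untested is meant among the compounds shown, and "the series" means these compounds.

Measured compounds:
compound 1 `COc1ccc(F)cc1CNCCCNc1ccnc2cc(Cc3ccc(F)cc3Cl)ccc12`, 9.47 in a physicochemical assay for acid dissociation
compound 2 `COc1ccc(F)cc1CNCCCNc1ccnc2cc(-c3cccc4ccccc34)ccc12`, 9.47 in this assay
compound 3 `COc1cccc(CNCCCNc2ccnc3cc(Cc4ccc(F)cc4Cl)ccc23)c1O`, 9.47 in this assay

The three measured compounds sit level with one another in this assay. The change naphthalen-1-yl in place of 2-chloro-4-fluorobenzyl on an aromatic carbon gives no change at the digits printed from compound 1 to compound 2 (within the scatter). The two cores differ by 2-hydroxy-3-methoxyphenyl in place of 5-fluoro-2-methoxyphenyl on a saturated chain carbon bound to an amine nitrogen, and that change gives no change at the digits printed from compound 1 to compound 3 (within the scatter). Compound 3 therefore stands with compounds 1 and 2 at the digits measured.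

Compound 4 `COc1cccc(CNCCCNc2ccnc3cc(-c4cccc5ccccc45)ccc23)c1O` is not yet measured in this assay. It arises from compound 3 by naphthalen-1-yl in place of 2-chloro-4-fluorobenzyl on an aromatic carbon, the same change as from compound 1 to compound 2, made on the core of compound 3 rather than the core of compound 1; the place is described in the same words in both cases. Since the change from compound 1 to compound 2 gave no change at the digits printed from compound 1 to compound 2 (within the scatter), and the core change from compound 1 to compound 3 gave no change at the digits printed from compound 1 to compound 3 (within the scatter), the step from compound 3 to compound 4 is expected to be no change at the digits printed from compound 3 to compound 4 (within the scatter) in this assay. Compound 4 is accordingly estimated at 9.47, expected to fall between 9.17 and 9.77.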

Compound 4, acid dissociation constant: 9.47
Estimate against measurement, compound 4: no gap at the digits printed; low and high end bracket the measured number.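

In this assay, naphthalen-1-yl in place of 2-chloro-4-fluorobenzyl on an aromatic carbon gives no change at the digits printed from compound 3 to compound 4 (within the scatter) on the core of compound 3, and 2-hydroxy-3-methoxyphenyl in place of 5-fluoro-2-methoxyphenyl gives no change at the digits printed from compound 2 to compound 4 (within the scatter) with naphthalen-1-yl in place. The change therefore carries from the core of compound 1 to the core of compound 3 with a step of the same printed size, but every step in this set of four compounds is null, so this shows agreement only for a change that leaves the read-out level, and not that a step of visible size would carry in the same way or that the result extends to other cores. No measurement on hand offers an explanation for the level values.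

Open, as far as these compounds go, is whether the read-out stays level when an amine or a carboxylic acid enters on that aromatic carbon, or when a longer chain takes the place of the saturated chain. A test of carrying a change from one core to another still needs a step beyond the scatter, and the compounds shown hold none.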